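Compound 3 to compound 4: acetyl gives way to tert-butoxycarbonyl

A few compounds are considered here, and "the series" means these few. Any claim that something is new, unique, unknown or untested is made for them only; others in the source may bear on it.

Measured so far in an ADME assay on RAW264.7 cells (Mus musculus) for cytotoxicity, read by MTT assay, with a stated time of 48 h, tested at 50 uM; a lower number here means less inhibition, a higher number more inhibition at the concentration tested (going by the name of the read-out):
Compound 1 `CC(C)(C)OC(=O)N1CCc2c(sc(NC(=O)c3ccc(Cl)cc3)c2C(N)=O)C1` gives 37.3%.
Compound 2 `NC(=O)c1c(NC(=O)c2ccc(OCc3ccccc3)cc2)sc2c1CCN(C(=O)c1ccccc1)C2` gives 13.7%.
Compound 3 `CC(=O)N1CCc2c(sc(NC(=O)c3ccc(OCc4ccccc4)cc3)c2C(N)=O)C1` gives 11.6%.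

Compound 3 has the lowest of the three numbers in this assay, but compound 2 sits within the scatter of it, so the two cannot be ordered; only compound 1 stands clearly higher. Going by the values given here, the one measured step on the ring-bound amide carbonyl is a number 2.1 percentage points lower from compound 2 to compound 3 (within the scatter), which changes nothing beyond the scatter.

Compound 4 `CC(C)(C)OC(=O)N1CCc2c(sc(NC(=O)c3ccc(OCc4ccccc4)cc3)c2C(N)=O)C1` differs from compound 3 as follows: tert-butoxy in place of methyl on a carbonyl carbon. Read one bond further out, this is acetyl to tert-butoxycarbonyl. Among the compounds with values here, no measured pair isolates this change. Compound 1 carries the tert-butoxycarbonyl group and gives a higher number, but it also differs in the other amide, so that gap cannot be attributed to the acyl group alone. Within the data shown here, the only acyl step measured, the one from compound 2 to compound 3, was flat.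

Compound 4 is therefore expected to move by a number 5.4 percentage points higher from compound 3 to compound 4 (within the scatter) in this assay, a step that may well stay within the scatter, with a modest upward lean. The estimate for compound 4 is 17%, with a range from 5% to 35%.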

Compound 4, a percentage reported as inhibition, at one concentration (the size of the read-out at that concentration, not a potency): 52.1%
The estimate for compound 4 lay 35.1 percentage points below the measured number, and the stated range ends below it.
By their numbers in this assay, from the lowest: compounds 3 and 2 (each within the scatter of the next); then compound 1; then compound 4.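

In this assay the group on the carbonyl carbon bound to the amide-type nitrogen in a ring turns out to matter: tert-butoxy in place of methyl gives a number 40.5 percentage points higher from compound 3 to compound 4 (beyond the scatter) and tert-butoxy in place of phenyl gives a number 38.4 percentage points higher from compound 2 to compound 4 (beyond the scatter) even though methyl in place of phenyl had given only a number 2.1 percentage points lower from compound 2 to compound 3 (within the scatter) at that carbon. With tert-butoxycarbonyl held fixed, benzyloxy in place of chloro on an aromatic carbon gives a number 14.8 percentage points higher from compound 1 to compound 4 (beyond the scatter) and so shows that the number also responds to this second place. Nothing available here accounts for these rises.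

Going by these compounds, whether the rise needs tert-butoxy itself, or would also follow from methoxy or ethoxy on that carbonyl carbon or from a free ring amine, remains open. Also open, on these data alone, is whether chloro and benzyloxy would differ in the same way with acetyl in place of tert-butoxycarbonyl.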